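A Branched Ether Chain on a Shared Core

The source may report more compounds than this note shows. Statements on the series, on what has been measured and on what is new or still open speak of the compounds shown alone.

Compound 1 `CC1(C)CCC(CN2CCN(c3ccc(C(=O)NS(=O)(=O)c4ccc(OCC5CCOCC5)c([N+](=O)[O-])c4)c(Oc4cnc5[nH]ccc5c4)c3)CC2)=C(c2ccc(C(F)(F)F)cc2)C1`, compound 2 `CC1(C)CCC(CN2CCN(c3ccc(C(=O)NS(=O)(=O)c4ccc(OCC5CCOC5)c([N+](=O)[O-])c4)c(Oc4cnc5[nH]ccc5c4)c3)CC2)=C(c2ccc(C(F)(F)F)cc2)C1` and compound 3 `CC1(C)CCC(CN2CCN(c3ccc(C(=O)NS(=O)(=O)c4ccc(OCC5CCCOC5)c([N+](=O)[O-])c4)c(Oc4cnc5[nH]ccc5c4)c3)CC2)=C(c2ccc(C(F)(F)F)cc2)C1` share one core and differ only in the ring on a saturated chain carbon bound to an oxygen on an aromatic ring. In a functional assay on RS4-11 cells (Homo sapiens) for inhibition, read by CCK-8 assay, with a stated time of 72 h (a higher number here means a weaker inhibitor, a lower number a stronger inhibitor), compound 1 gives 5.9 nM while compound 2 gives 47 nM and compound 3 gives 12 nM in the same test. Compound 3 therefore stands in the middle of the three numbers, nearer to compound 1 than to compound 2.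

The next compound is compound 4 `CC(Oc1ccc(S(=O)(=O)NC(=O)c2ccc(N3CCN(CC4=C(c5ccc(C(F)(F)F)cc5)CC(C)(C)CC4)CC3)cc2Oc2cnc3[nH]ccc3c2)cc1[N+](=O)[O-])C1CCOCC1`, with 1-(oxan-4-yl)ethyl in place of (oxan-3-yl)methyl on an oxygen on an aromatic ring. Two parts of this change can be weighed. The ring returns to the oxan-4-yl of compound 1, and the measured 2.0-fold higher number from compound 1 to compound 3 (0.31 log units; beyond the scatter) suggests a modest move toward a lower number. The steps of an 8.0-fold higher number from compound 1 to compound 2 (0.90 log units; beyond the scatter) and a 3.9-fold lower number from compound 2 to compound 3 (0.59 log units; beyond the scatter) show that this series responds to the ring, though only modestly. For the measured compounds named here, no measured compound carries the branched chain, so its contribution is unknown and could cancel that gain. The expected change is a 1.2-fold lower number from compound 3 to compound 4 (0.08 log units; within the scatter) and no shift beyond the scatter is expected. For compound 4 the estimated value in this assay is 10 nM with an expected range from 3 nM to 35 nM.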

Compound 4, half-maximal inhibitory concentration: 269 nM
For compound 4 the middle estimate is 27-fold (1.43 log units) below the measured one; measured number outside the range, above it.
By their numbers in this assay, from the lowest: compound 1; then compound 3; then compound 2; then compound 4.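

The clearest reading comes from the methyl in place of hydrogen on the saturated chain carbon, where in this assay this one addition gives a 46-fold higher number from compound 1 to compound 4 (1.66 log units; beyond the scatter) and the oxan-4-yl ring, which carries the lowest number in the set, ends up with the highest. The chain carbon bound to the oxygen on the aromatic ring therefore matters more here than the choice of ring did, for the other two steps, a 22-fold higher number from compound 3 to compound 4 (1.35 log units; beyond the scatter) and a 5.7-fold higher number from compound 2 to compound 4 (0.76 log units; beyond the scatter), also rise and place compound 4 above every compound that differs only in its ring. The compounds shown offer nothing that accounts for the size of this rise.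

From the compounds shown here alone, whether the methyl would cost as much on the oxan-3-yl or oxolan-3-yl rings stays open, since the branch appears on the oxan-4-yl ring alone. Also open, going by these compounds, is how this position would respond to a 2-(oxan-4-yl)ethyl chain, which would place the extra carbon in a straight chain, or to a hydroxymethyl group or an amine on the same chain carbon in place of the methyl.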